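The source may hold more compounds than are shown below. What is called first, only, known or untested is meant among the compounds shown, and "the series" means these compounds.

Of the compounds shown here, three of a shared core have been measured in a functional assay on U-87MG ATCC cells for antiproliferative activity against U-87 MG (Homo sapiens), read by MTT assay, with a stated time of 72 h; a lower number here means a stronger inhibitor, a higher number a weaker inhibitor. Compound 1 `Cc1nn(C)c(Oc2ccc(Cl)cc2)c1/C=N\CCCCCOc1cc2oc(=O)cc(C)c2cc1Cl` gives 18700 nM in this assay. Compound 2 `Cc1nn(C)c(Oc2ccc(I)cc2)c1/C=N\CCCCCOc1cc2oc(=O)cc(C)c2cc1Cl` in this assay returns > 25000 nM, a limit of the assay rather than a number. Compound 3 `Cc1nn(C)c(Oc2ccc(F)cc2)c1/C=N\CCCCCCOc1cc2oc(=O)cc(C)c2cc1Cl` gives 16700 nM in this assay, the lowest of the two numbers shown, and its gap to compound 1 lies within the scatter. Compound 4 `Cc1nn(C)c(Oc2ccc(I)cc2)c1/C=N\CCCCCCOc1cc2oc(=O)cc(C)c2cc1Cl` has not yet been measured. The change from compound 3 to compound 4 is as follows: iodo in place of fluoro on an aromatic carbon. For the measured compounds named here, the one measured step that bears on it is an at least 1.3-fold higher number from compound 1 to compound 2 (0.12 log units; that floor lies within the scatter), which likewise brings in iodo on the same ring and ends at the limit of > 25000 nM in this assay, at which 1 of the 3 values shown sits. A rise in the number is therefore expected from compound 3 to compound 4, with a real chance that the assay again reports only a limit, although the floor of the measured step sits within the scatter. Compound 4 is expected to give 30000 nM, between 15000 nM and 60000 nM. That expectation means a step of a 1.8-fold higher number from compound 3 to compound 4 (0.25 log units; within the scatter).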

Compound 4, half-maximal inhibitory concentration: 16800 nM
The estimate for compound 4 lay 1.8-fold (0.25 log units) above the measured number, and the stated range covers the measured number.
By their numbers in this assay, from the lowest: compounds 3, 4 and 1 (each within the scatter of the next). At a limit, above all of these: compound 2.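

In this assay, replacing 4-fluorophenoxy with 4-iodophenoxy gives a 1.0-fold higher number from compound 3 to compound 4 (0.00 log units; within the scatter), so on this chain the two halogens cannot be told apart at this position. Compound 4 also returns a number, which shows that iodo at this place does not by itself carry a compound to the limit of the assay. Compound 2, with the same iodo group on a shorter chain, remains a limit and not a number: the limit of > 25000 nM in this assay, at which 1 of the 4 values shown sits.

With that limit, the compounds shown cannot say how much the chain length itself contributes to the read-out among the iodo compounds. They also leave open whether an amine or a carboxylic acid in place of the halogen, or a longer chain, would move the number beyond the scatter.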